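This account rests on a few compounds, and the source may have more. Where it says the series, first, only, none or still open, it means among the compounds named here.

Measured in a functional assay on isolated protein for inhibition of Glucose-dependent insulinotropic receptor (Homo sapiens), read by HTRF and cAMP accumulation; a lower number here means that less compound is needed, a higher number that more compound is needed for the effect:
compound 1 `Cc1nc(S(C)(=O)=O)ccc1Oc1ncnc(OC2CCN(C(=O)OC(C)F)CC2)c1F` gives 65.5 nM;
compound 2 `Cc1nc(S(C)(=O)=O)ccc1Oc1ncnc(OC2CCN(C(=O)SC3(C)CC3)CC2)c1F` gives 13.2 nM.

Compound 2 holds the lower of the two numbers. Among the compounds with values here, the only other measured compound, compound 1, stands above it by a 5.0-fold lower number from compound 1 to compound 2 (0.70 log units; beyond the scatter), a change that alters the atom on the carbonyl carbon and the group beyond it at the same time. Compound 3 `Cc1nc(S(C)(=O)=O)ccc1Oc1ncnc(OC2CCN(C(=O)SC3CCC3)CC2)c1F` keeps all of compound 2 and differs only in cyclobutyl in place of 1-methylcyclopropyl on a sulfur. Within the data shown here, no measured step bears directly on this rearrangement of the same atoms: the step from compound 1 to compound 2 does not isolate what the ring on the sulfur contributes, and nothing else has been measured. Among the measured compounds shown here, with one step in hand and none that tests a ring size change on the sulfur, the step expected in this assay is a 1.1-fold higher number from compound 2 to compound 3 (0.06 log units; within the scatter), that is, nothing beyond the usual scatter, with the broad range reflecting that the change has no precedent here. Compound 3 is therefore estimated at 15 nM, within a range from 6 nM to 40 nM.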

Compound 3, half-maximal effective concentration: 8.51 nM
Beside the measured number, compound 3's estimate is 1.8-fold (0.25 log units) above it; low and high end bracket the measured number.
By their numbers in this assay, from the lowest: compounds 3 and 2 (each within the scatter of the next); then compound 1.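

In this assay, cyclobutyl in place of 1-methylcyclopropyl on a sulfur gives a 1.6-fold lower number from compound 2 to compound 3 (0.19 log units; within the scatter) and so leaves the reading unchanged within the scatter, which shows that this position accepts either of these two small carbon rings, a point compound 1 and compound 2 alone could not settle. The second sulfur compound also stands clear of the fluorinated compound, with a 7.7-fold lower number from compound 1 to compound 3 (0.89 log units; beyond the scatter) matching in direction the earlier 5.0-fold lower number from compound 1 to compound 2 (0.70 log units; beyond the scatter), so both compounds with a ring on the sulfur lie beyond the scatter from compound 1, although each of these steps still changes the atom on the carbonyl carbon and the group beyond it together. Nothing measured here offers an explanation for these readings.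

The compounds shown leave open how much of the gap from compound 1 belongs to the sulfur itself and how much to the ring, a question that cyclobutyl on an oxygen in the same place would address. They also leave open whether a larger ring such as cyclopentyl, or an open chain such as isopropyl, would read like cyclobutyl on the sulfur.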